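A few compounds are considered here, and "the series" means these few. Any claim that something is new, unique, unknown or untested is made for them only; others in the source may bear on it.

Compound 2 (`CN(C)[C@@H]1CCN(c2cccc3c2C[C@H](CN(C)[C@H]2CCCc4cccnc42)NC3)C1`) carries the entry "not determined" (no result reported) in an ADME assay on microsomes from liver (Homo sapiens) for metabolic stability, using NADPH, with a stated time of 10 min (on this read-out higher numbers stand for a more stable compound and lower numbers for a less stable compound), and so has no place on this scale. In this assay, among the compounds with values here, compound 1 (`CN(C[C@H]1Cc2c(cccc2N2CCC(N)CC2)CN1)[C@H]1CCCc2cccnc21`) gives 80.8% and is the only compound here with a number. Compound 3 (`CN1CC[C@H]2CN(c3cccc4c3C[C@H](CN(C)[C@H]3CCCc5cccnc53)NC4)C[C@H]21`) differs from compound 2 in one place, on an aromatic carbon: a group of 9 heavy atoms (7 carbon, 2 nitrogen; 2 five-membered non-aromatic rings with 1 hetero atom each) in place of a group of 8 heavy atoms (6 carbon, 2 nitrogen; one five-membered non-aromatic ring with 1 hetero atom), on an aromatic carbon is the whole change, and the rest of the structure stays the same. With no number for compound 2, the data cannot size this step. The expectation in this assay is a step no larger than the usual scatter, in no particular direction. The only anchor for the level is compound 1 at 80.8% and the estimate sits a little under it, with a wide margin. For compound 3 the expected value is 75% with an estimated range of 55% to 92% for a single measurement.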

Compound 3, percent of the compound remaining: 87.3%
The estimate for compound 3 lay 12.3 percentage points below the measured number, within the range that was stated.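

In this assay, the group with 2 five-membered non-aromatic rings, placed on an aromatic carbon of the shared core in place of the group with one six-membered non-aromatic ring, gives a number 6.5 percentage points higher from compound 1 to compound 3 (within the scatter). On this read-out, the two groups therefore cannot be told apart, and this position holds either one without a change beyond the scatter. Nothing measured here offers an explanation for this result.

The step that involves compound 2 cannot be read, as compound 2 has no number to compare with. From the compounds shown here alone, whether a morpholine ring or a carboxylic acid on this same aromatic carbon would leave the result within the scatter, or move it clearly, remains open.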